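The compounds below may be only part of what the source reports. "The series", "measured", "known", "first", "only" and "open" are said of these compounds alone.

In an assay on CHO cells for binding affinity to Alpha-2B adrenergic receptor (Homo sapiens), read by radioligand binding (on this read-out lower numbers stand for stronger inhibition and higher numbers for weaker inhibition), compound 2 `CSc1ccc(F)cc1NCC1=NCCN1` gives 331 nM. Compound 1 `CS(=O)(=O)c1ccc(F)cc1NCC1=NCCN1` differs from it by methylsulfonyl in place of methylsulfanyl on an aromatic carbon. In this assay compound 1 gives < 6310 nM, a limit of the assay and not a number. The step that the limit leaves unreadable from compound 2 to compound 1 is therefore unreadable, as the limit of < 6310 nM in this assay, at which 1 of the 3 values shown sits, shows. Compound 3 `CSc1c(F)cccc1NCC1=NCCN1` has the same atoms as compound 2, joined differently; the difference between the two cores is not broken down here. In this assay compound 3 gives 3980 nM. Compound 4 `CS(=O)(=O)c1c(F)cccc1NCC1=NCCN1` is not yet measured and differs from compound 3 by methylsulfonyl in place of methylsulfanyl on an aromatic carbon, the same kind of change as from compound 2 to compound 1, the place here being ortho to a fluoro group rather than para to it. Compound 4 is expected to give 20000 nM, between 5000 nM and 80000 nM. The expected step is a 5.0-fold higher number from compound 3 to compound 4 (0.70 log units; beyond the scatter). This rests on compound 1 reaching only (the limit of < 6310 nM in this assay, at which 1 of the 3 values shown sits).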

Compound 4, inhibition constant: < 6310 nM
Compound 4: only a limit was reported; the forecaster's own chance of this, stated with the estimate: 70%; middle value at least 3.1-fold (0.50 log units) from the limit.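

The step from compound 3 to compound 4 cannot be read, since compound 4, like compound 1, is reported only as a limit: the limit of < 6310 nM in this assay, at which 2 of the 4 values shown sit. The compounds shown leave open how large the change from methylsulfanyl to methylsulfonyl is in either pair.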